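Trifluoromethyl in Place of Carbamoyl on the Aryl Piperazine

The source may hold more compounds than are shown below. What is called first, only, known or untested is meant among the compounds shown, and "the series" means these compounds.

Measured so far:
compound 1, `COc1ccc(-c2nc(C)oc2C(=O)N2CCN(c3cccc(Cl)c3)CC2)cc1`: "not active" (no number reported)
compound 2, `CCc1nc(-c2ccc(OC)cc2)c(C(=O)N2CCN(c3cccc(Cl)c3)CC2)o1`: > 1000 nM
compound 3, `Cc1nc(-c2ccccc2)c(C(=O)N2CCN(c3cccc(C(N)=O)c3)CC2)o1`: 71 nM

Of the compounds shown here, three have been tested in a functional assay on HL-60 cells (Homo sapiens) for inhibition, read by MTT assay, with a stated time of 72 h; on this read-out higher numbers stand for weaker inhibition and lower numbers for stronger inhibition. Compound 1 gave no number and is recorded as "not active" (no number reported). For compound 2 the result is a limit of the assay, > 1000 nM, and not a number, a point also noted in the limit of > 1000 nM in this assay, at which 1 of the 3 values shown sits. Among the measured compounds shown here, compound 3 is therefore the only compound with a measured value, 71 nM, and it stands alone at the potent end of what has been seen. Compounds 1 and 2 differ from compound 3 in more than one place, so their values show only that they are weaker, not which change is responsible.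

Compound 4 `Cc1nc(-c2ccccc2)c(C(=O)N2CCN(c3cccc(C(F)(F)F)c3)CC2)o1` has not been measured. It differs from compound 3 in one place: trifluoromethyl in place of carbamoyl on an aromatic carbon. For the measured compounds named here, with no measured step to lean on, the expectation rests on the change itself, and the guess is that the trifluoromethyl compound will be somewhat weaker. Compound 4 is estimated at 400 nM, with a range of 100 nM to 2500 nM. This corresponds to an expected step of a 5.6-fold higher number from compound 3 to compound 4 (0.75 log units; beyond the scatter), a loss that is expected to exceed the usual scatter, though a result near compound 3 would not be surprising.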

Compound 4, half-maximal inhibitory concentration: 153 nM
Estimate against measurement, compound 4: 2.6-fold (0.42 log units) above; measured number inside the range.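

In this assay, among the compounds shown here, replacing carbamoyl with trifluoromethyl on the aryl piperazine gives a 2.2-fold higher number from compound 3 to compound 4 (0.33 log units; beyond the scatter), the first measured step in which only this group changes. Compound 4 has neither the hydrogen-bond donor nor the hydrogen-bond acceptor of carbamoyl, yet it still gives a measured number, so neither is required for a measured value at this place, and the price of the change is modest. No measurement shown bears on why the number moves.

As far as these compounds go, it remains open whether a nitrile, an amine or a carboxylic acid at this place would give a value close to those of compound 3 and compound 4. Also open, from the compounds shown here alone, is whether the same change would give a similar step with the other substituents of compound 1 and compound 2 on the shared core.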